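Benzyl fluoro swap on the 5-fluorouracil-type ester series

A few compounds are considered here, and "the series" means these few. Any claim that something is new, unique, unknown or untested is made for them only; others in the source may bear on it.

Values in a functional assay on Bel7402/5-FU cells (Homo sapiens) for antiproliferative activity, read by MTT assay, with a stated time of 72 h; a higher number here means a weaker inhibitor, a lower number a stronger inhibitor:
- Compound 1 `C=C1C(=O)O[C@H]2[C@H]1CC/C(COC(=O)Cn1cc(F)c(=O)[nH]c1=O)=C\CC[C@@]1(C)O[C@@H]21`: > 20000 nM, a limit
- Compound 2 `C=C1C(=O)O[C@H]2[C@H]1CC/C(Cn1cc(Cn3cc(F)c(=O)[nH]c3=O)nn1)=C\CC[C@@]1(C)O[C@@H]21`: > 20000 nM, a limit
- Compound 3 `C=C1C(=O)O[C@H]2[C@H]1CC/C(COC(=O)Cn1cc(F)c(=O)n(Cc3ccccc3)c1=O)=C\CC[C@@]1(C)O[C@@H]21`: 4270 nM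

Compound 3 is the only one of the three with a real number, at 4270 nM. The other two values are limits. Two of the three entries sit at the limit of > 20000 nM in this assay, at which 2 of the 3 values shown sit.

The next compound to be measured is compound 4 `C=C1C(=O)O[C@H]2[C@H]1CC/C(COC(=O)Cn1cc(F)c(=O)n(Cc3ccc(F)cc3)c1=O)=C\CC[C@@]1(C)O[C@@H]21`. Its difference from compound 3 is fluoro in place of hydrogen on an aromatic carbon. This is fluoro in place of hydrogen on an aromatic carbon, para to a large group, so benzyl becomes 4-fluorobenzyl.

Within the data shown here, only one measured step bears on this change. It is an at least 4.6-fold lower number from compound 1 to compound 3 (0.67 log units; beyond the scatter), with benzyl in place of hydrogen on an aromatic nitrogen, and it starts from a limit. That step shows that adding the benzyl group counts in this assay, but it says nothing about substitution on the benzyl ring itself. Among the measured compounds shown here, no measured step covers a change of that kind, and the change here is a single atom on a group already present. The working expectation is therefore no shift beyond the scatter, in either direction.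

The expected step is a 1.1-fold lower number from compound 3 to compound 4 (0.03 log units; within the scatter). In this assay the estimate for compound 4 is 4000 nM, with an expected range of 1700 nM to 10000 nM.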

Compound 4, half-maximal inhibitory concentration: 1140 nM
Compound 4: middle estimate off by 3.5-fold (0.55 log units), on the high side, outside the stated range (below it).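

In this assay, a single atom on the benzyl ring moves the number: the change to 4-fluorobenzyl gives a 3.7-fold lower number from compound 3 to compound 4 (0.57 log units; beyond the scatter), so this ring carbon, para to a large group, is a place where substitution counts. Among these compounds, until now, the only readable change was the addition of the benzyl group to the aromatic nitrogen, which said nothing about the ring beyond that nitrogen. Taken as one change on that nitrogen, 4-fluorobenzyl in place of hydrogen gives an at least 17-fold lower number from compound 1 to compound 4 (1.24 log units; beyond the scatter), a size that is only a bound because the value of compound 1 is a limit: the limit of > 20000 nM in this assay, at which 2 of the 4 values shown sit.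

As far as these compounds go, whether this gain belongs to fluoro itself or would appear with any group at this carbon stays open, and a chloro, methoxy or amino group on the same ring would separate those readings. Also open, from the compounds shown here alone, is whether 4-fluorobenzyl on the aromatic nitrogen would give a similar step on the linker of compound 2, and whether a longer chain between that nitrogen and the ring would keep it.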